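From 2-hydroxyphenyl to 3-hydroxyphenyl in compound 3

The source may report more compounds than this note shows. Statements on the series, on what has been measured and on what is new or still open speak of the compounds shown alone.

In a functional assay, with a stated time of 30 min (on this read-out higher numbers stand for weaker inhibition and lower numbers for stronger inhibition), compound 1 (`O=C(/C=C/c1cccc(O)c1)/C=C/c1ccc(O)c(O)c1`) gives 71000 nM and compound 2 (`O=C(/C=C/c1ccc(O)c(O)c1)/C=C/c1cc(O)ccc1O`) gives 25000 nM on the same scale. Compound 3 (`O=C(/C=C/c1ccccc1O)CC(=O)c1ccc(O)c(O)c1`) stands at 16000 nM which is within the scatter of the value of compound 2 and beyond the scatter of compound 1, whose number is higher.

The change to compound 4 (`O=C(/C=C/c1cccc(O)c1)CC(=O)c1ccc(O)c(O)c1`) is 3-hydroxyphenyl in place of 2-hydroxyphenyl on a double-bonded chain carbon bound to a double-bonded chain carbon with 3-hydroxyphenyl in place of 2-hydroxyphenyl on a double-bonded chain carbon bound to a double-bonded chain carbon. For the measured compounds named here, the one measured step is a 2.8-fold lower number from compound 1 to compound 2 (0.45 log units; beyond the scatter) and it is modest, but it is hydroxy in place of hydrogen on an aromatic carbon, so it bears on this exchange only loosely. Going by the values given here, no measured pair isolates the exchange. Compound 1 also carries 3-hydroxyphenyl and gives 71000 nM on a different chain, so a small move toward a higher number is expected, not clearly beyond the scatter. The estimated step is a 1.5-fold higher number from compound 3 to compound 4 (0.18 log units; within the scatter) for this exchange. For compound 4 the expected value is 24000 nM with an estimated range of 10000 nM to 58000 nM in this read-out.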

Compound 4, half-maximal inhibitory concentration: 10000 nM
The estimate for compound 4 lay 2.4-fold (0.38 log units) above the measured number, within the range that was stated.
By their numbers in this assay, from the lowest: compounds 4, 3 and 2 (each within the scatter of the next, the first and the last beyond it); then compound 1.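

In this assay, the exchange of 2-hydroxyphenyl for 3-hydroxyphenyl on a double-bonded chain carbon bound to a double-bonded chain carbon can now be read directly (a 1.6-fold lower number from compound 3 to compound 4 (0.20 log units; within the scatter)). On the chain shared by compound 3 and compound 4, this reading does not separate the two hydroxyphenyl groups, so the place accepts either without a difference beyond the scatter. Nothing measured offers an explanation for this result.

Still open, from the compounds shown here alone, is whether a hydroxy is needed at this place at all, which a methoxy or an amine on the phenyl ring would test. For the compounds shown here, also open is whether the two hydroxyphenyl groups remain indistinguishable on the chain of compound 1 and compound 2, where no pair isolates this exchange.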